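Primary Amide to Pyrrolidine Amide on the Shared Core

The source may hold more compounds than are shown below. What is called first, only, known or untested is meant among the compounds shown, and "the series" means these compounds.

Compound 1, `O=C(O)CCCc1ccc(NCc2cccc(Oc3ccccc3)c2)cc1`: 1120 nM
Compound 2, `O=C(O)[C@H]1C[C@@H]1c1ccc(NCc2cccc(Oc3ccccc3)c2)cc1`: 12.3 nM; 13.5 nM (2 entries)
Compound 3, `NC(=O)CCc1ccc(NCc2cccc(Oc3ccccc3)c2)cc1`: 51.3 nM

In a functional assay on CHO cells for agonist activity at Free fatty acid receptor 1 (Homo sapiens) (a lower number here means that less compound is needed, a higher number that more compound is needed for the effect), compound 1 gives 1120 nM and compound 3 gives 51.3 nM. Among the two compounds that carry an open chain ending in a carbonyl on the shared core, compound 3 has the lower number, and the only measured step that changes a single place is a 22-fold lower number from compound 1 to compound 3 (1.34 log units; beyond the scatter). Compound 2, whose several entries read (the several entries of compound 2 in this assay, 12.3 nM; 13.5 nM (2 entries)), differs from compound 3 in more than one place, so only its values can be set beside those of compound 3; they are lower.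

Compound 4, `O=C(CCc1ccc(NCc2cccc(Oc3ccccc3)c2)cc1)N1CCCC1`, is the next compound. It differs from compound 3 by pyrrolidin-1-yl in place of amino on a carbonyl carbon. Within the data shown here, no measured step touches the substituents on the amide nitrogen: the step of a 22-fold lower number from compound 1 to compound 3 (1.34 log units; beyond the scatter) exchanges the acid for the amide and says nothing about what a ring in place of the amino group does. With nothing to carry over, the expectation is a modest shift toward a higher number, a 2.3-fold higher number from compound 3 to compound 4 (0.37 log units; beyond the scatter), which may still fall within the scatter. Compound 4 is therefore estimated at 120 nM in this assay, with a range from 25 nM to 600 nM.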

Compound 4, half-maximal effective concentration: 115 nM
Compound 4: the middle estimate sits 1.0-fold (0.02 log units) above what was measured, and the stated range covers the measured number.
By their numbers in this assay, from the lowest: compound 3; then compound 4; then compound 1.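

In this assay, the position on the carbonyl carbon tolerates a much larger group than amino: replacing amino with pyrrolidin-1-yl adds a five-membered ring and removes the hydrogen-bond donor of the amino group, yet gives only a 2.2-fold higher number from compound 3 to compound 4 (0.35 log units; beyond the scatter) as a modest change, though one beyond the scatter. The lower number relative to the acid is also not confined to the primary amide, since the ring amide still shows a 9.7-fold lower number from compound 1 to compound 4 (0.99 log units; beyond the scatter) even though its nitrogen carries no hydrogen. The measurements shown do not bear on why replacing amino with this ring moves the number by so little.

The compounds shown leave open how the number responds to smaller or differently shaped groups on the amide nitrogen, such as methylamino, dimethylamino, piperidin-1-yl or morpholin-4-yl, and so whether the five-membered ring has any special standing among them. They also leave open whether a longer chain between the aromatic ring and the amide carbonyl would keep the number near those of the two amides.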